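A few compounds are considered here, and "the series" means these few. Any claim that something is new, unique, unknown or untested is made for them only; others in the source may bear on it.

Among the measured compounds shown here, compound 2 `Cc1nc(C)n(CC(=O)N2CCN(c3sc(C(F)(F)F)nc3-c3nc4ccccc4[nH]3)C[C@H]2C)n1` is one of two compounds measured in a functional assay on Venous blood for antagonist activity at C-X-C chemokine receptor type 3 (Homo sapiens), read by flow cytometry, with a stated time of 30 min, in the presence of a further agent that is not named here; a higher number here means a weaker inhibitor, a lower number a stronger inhibitor. Of those two numbers compound 2 gives the lowest, 237 nM, while compound 1 `C[C@@H]1CN(c2sc(C(F)(F)F)nc2-c2nc3ccccc3[nH]2)CCN1C(=O)Cn1ccc(C(=O)O)n1` gives 5570 nM. For the measured compounds named here, the only recorded step between them, a 24-fold lower number from compound 1 to compound 2 (1.37 log units; beyond the scatter), shows that the group attached to this saturated chain carbon can move the result a long way. Compound 3 `C[C@@H]1CN(c2sc(C(F)(F)F)nc2-c2nc3ccccc3[nH]2)CCN1C(=O)Cn1cc(C2CCN(C)CC2)cn1` has not yet been measured; it differs from compound 2 in the same place: 4-(1-methylpiperidin-4-yl)-1H-pyrazol-1-yl in place of 3,5-dimethyl-1H-1,2,4-triazol-1-yl on a saturated chain carbon bound to a carbonyl carbon. Going by the values given here, because the single relevant step a 24-fold lower number from compound 1 to compound 2 (1.37 log units; beyond the scatter) concerns a different exchange, it indicates how much such a swap can matter but not which way this one will go. The expected step of a 1.7-fold higher number from compound 2 to compound 3 (0.23 log units; within the scatter) is therefore modest and uncertain, with a wide margin on either side. Compound 3 is estimated at 400 nM, within a range from 80 nM to 2000 nM.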

Compound 3, half-maximal inhibitory concentration: 1690 nM
Estimate against measurement, compound 3: 4.2-fold (0.63 log units) below; the range from low to high includes it.
By their numbers in this assay, from the lowest: compound 2; then compound 3; then compound 1.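

In this assay the exchange at this saturated chain carbon gives a 7.1-fold higher number from compound 2 to compound 3 (0.85 log units; beyond the scatter) and so shows that a group of 12 heavy atoms with two rings does not match the 3,5-dimethyl-1H-1,2,4-triazol-1-yl group of 7 heavy atoms and one ring. The same 4-(1-methylpiperidin-4-yl)-1H-pyrazol-1-yl group still gives a 3.3-fold lower number from compound 1 to compound 3 (0.52 log units; beyond the scatter) when it replaces the 3-carboxy-1H-pyrazol-1-yl group, which places compound 3 clearly between the other two. No supporting measurement explains why these three groups differ.

As far as these compounds go, compound 3 changes the aromatic ring and adds a methylpiperidine in a single exchange, so the share of each change stays open. An unsubstituted pyrazole or a 4-(piperidin-4-yl)-1H-pyrazol-1-yl group, lacking the methyl on nitrogen, would help separate them.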